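The compounds below may be only part of what the source reports. "The series", "measured", "known", "first", "only" and "open" are said of these compounds alone.

Compound 1 `CCC(C)c1cc(C=O)cc2cc(C(C)=O)c(=O)oc12` was tested in a functional assay on NIH3T3 cells (Mus musculus) for cytotoxicity, read by sulforhodamine B assay, with a stated time of 48 h (a higher number here means a weaker inhibitor, a lower number a stronger inhibitor), and gave "not active" (no number reported), so no numerical value places it on the scale; it simply showed no measurable effect. Two related compounds carry the same core with an aldehyde replaced by a longer unsaturated ketone arm: compound 2 `CCOC(=O)c1cc2cc(/C=C/C(=O)c3ccc(Cl)cc3)cc(C(C)CC)c2oc1=O` gives 38400 nM in this assay, and compound 3 `CCC(C)c1cc(/C=C/C(=O)c2ccc(Cl)cc2)cc2cc(C(=O)OC)c(=O)oc12` gives 42400 nM. Among the compounds with values here, the only step between measured compounds, a 1.1-fold higher number from compound 2 to compound 3 (0.04 log units; within the scatter), concerns the ester chain and lies within the scatter. Compound 4 `CCC(C)c1cc(C=O)cc2cc(C(=O)OC)c(=O)oc12` differs from compound 1 by methoxy in place of methyl on a carbonyl carbon. No measured step covers this change, so nothing shown tells how large its effect should be or in which direction; the step from compound 2 to compound 3, touching a different place, offers only weak guidance that small changes on the ester part moved little. Given that compound 1 registered no effect, compound 4 is expected to remain a weak inhibitor, estimated near 60000 nM, with a plausible range from 20000 nM to 200000 nM, and a good chance that only inactivity is reported.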

Compound 4, half-maximal inhibitory concentration: "not active" (no number reported)
Compound 4 has no reported number here, and the estimate cannot be compared.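

Compound 1 and compound 4 both lack a number on this scale, so no step can be read for the change from acetyl to methoxycarbonyl. On these data alone, what stays open is whether this change alters cytotoxicity at all. Nothing shown offers an explanation for either result.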